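Methyl on the indole-type core: from compound 3 to compound 4

The compounds below may be only part of what the source reports. "The series", "measured", "known", "first", "only" and "open" are said of these compounds alone.

Compound 1, `COc1cc(Sc2c[nH]c3ccccc23)cc(OC)c1OC`, gives 34 nM in a functional assay on MCF7 cells (Homo sapiens) for inhibition, with a stated time of 48 h; a lower number here means a stronger inhibitor, a higher number a weaker inhibitor.
Compound 2, `COc1cc(Sc2c(C)[nH]c3ccccc23)cc(OC)c1OC`, gives 46 nM in this assay.
Compound 3, `COc1ccc2[nH]cc(Sc3cc(OC)c(OC)c(OC)c3)c2c1`, gives 22 nM in this assay.

Compound 4, `COc1ccc2[nH]c(C)c(Sc3cc(OC)c(OC)c(OC)c3)c2c1`, has not yet been measured. Its core differs from that of compound 1 by methoxy in place of hydrogen on an aromatic carbon, a change that gave a 1.5-fold lower number from compound 1 to compound 3 (0.19 log units; within the scatter). The change from compound 3 to compound 4 is methyl in place of hydrogen on an aromatic carbon. The same change has been made once before, from compound 1 to compound 2, where it is methyl in place of hydrogen on an aromatic carbon and gave a 1.4-fold higher number from compound 1 to compound 2 (0.13 log units; within the scatter). The two places are described in the same words, so this is the same change on a core that differs only by the methoxy group.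

On that basis the step is expected to be a 1.4-fold higher number from compound 3 to compound 4 (0.13 log units; within the scatter), resting on a 1.4-fold higher number from compound 1 to compound 2 (0.13 log units; within the scatter), with no further evidence on how the methoxy-bearing core responds to this change. Compound 4 is therefore estimated at 30 nM in this assay, with a likely range from 15 nM to 65 nM.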

Compound 4, half-maximal inhibitory concentration: 18 nM
The estimate for compound 4 lay 1.7-fold (0.22 log units) above the measured number, within the range that was stated.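

In this assay, methyl in place of hydrogen on an aromatic carbon gave a 1.2-fold lower number from compound 3 to compound 4 (0.09 log units; within the scatter), and this step does not differ from the one seen earlier on the core without the methoxy group: the same change on two cores in this assay, a 1.4-fold higher number (0.13 log units; within the scatter) from compound 1 to compound 2 and a 1.2-fold lower number (0.09 log units; within the scatter) from compound 3 to compound 4, 1.7-fold (0.22 log units) apart, within the scatter of two such steps. Adding the methoxy group to the core that carries the methyl gave a 2.6-fold lower number from compound 2 to compound 4 (0.41 log units; beyond the scatter), which is beyond the scatter taken alone, yet it does not differ from the earlier methoxy step: the same change on two cores in this assay, a 1.5-fold lower number (0.19 log units; within the scatter) from compound 1 to compound 3 and a 2.6-fold lower number (0.41 log units; beyond the scatter) from compound 2 to compound 4, 1.7-fold (0.22 log units) apart, within the scatter of two such steps. Both changes therefore carried from one core to the other within the scatter, but the two comparisons rest on the same four compounds in a single assay, so they do not show that either change would transfer to other cores in the series, and neither methyl step is large enough to fix a direction.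

The compounds shown leave open what ethyl, a longer chain or an amine would do in place of the methyl. They also leave open whether a hydroxyl or a fluorine in place of the methoxy would transfer between these cores in the same way.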